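Swapping the piperidin-3-yl amide for methylcarbamoyl

A few compounds are considered here, and "the series" means these few. Any claim that something is new, unique, unknown or untested is made for them only; others in the source may bear on it.

Of the compounds shown here, three sharing one core have been tested in a functional assay on MDA-MB-231 cells (Homo sapiens) for inhibition, read by MTT assay, with a stated time of 72 h (a higher number here means a weaker inhibitor, a lower number a stronger inhibitor), so far. Compound 1 (`COc1ccccc1-c1csc2cnc(Nc3ccc(NC(=O)C4CCNCC4)cc3)nc12`) gives 1050 nM in that test, compound 2 (`COc1ccccc1-c1csc2cnc(Nc3ccc(NC(=O)[C@H]4CCCNC4)cc3)nc12`) gives 440 nM and compound 3 (`COc1ccccc1-c1csc2cnc(Nc3ccc(NC(=O)CN)cc3)nc12`) gives 2770 nM there. Compound 2 therefore has the lowest number of the three and is the strongest inhibitor among them.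

Compound 4 (`CNC(=O)c1ccc(Nc2ncc3scc(-c4ccccc4OC)c3n2)cc1`) has not yet been measured. It carries methylcarbamoyl in place of ((piperidin-3-yl)carbonyl)amino on an aromatic carbon.

Among the measured compounds shown here, no measured compound carries methylcarbamoyl, so the known steps offer only indirect guidance. The closest is a 6.3-fold higher number from compound 2 to compound 3 (0.80 log units; beyond the scatter) when aminomethyl replaces piperidin-3-yl, as compound 3 also lacks the six-membered non-aromatic ring. Swapping piperidin-4-yl for piperidin-3-yl gave a 2.4-fold lower number from compound 1 to compound 2 (0.38 log units; beyond the scatter) as a smaller shift. A step of similar size to the first is therefore expected in this assay towards a higher number, meaning a weaker inhibitor. The estimated step is a 4.5-fold higher number from compound 2 to compound 4 (0.66 log units; beyond the scatter) in size. The estimated value for compound 4 is 2000 nM (range 600 nM to 7000 nM).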

Compound 4, half-maximal inhibitory concentration: 2120 nM
The estimate for compound 4 lay 1.1-fold (0.03 log units) below the measured number; the measured number falls inside the stated range.
By their numbers in this assay, from the lowest: compound 2; then compound 1; then compounds 4 and 3 (each within the scatter of the next).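

In this assay, replacing ((piperidin-3-yl)carbonyl)amino with the smaller, ring-free methylcarbamoyl gives a 4.8-fold higher number from compound 2 to compound 4 (0.68 log units; beyond the scatter), while the same replacement of ((piperidin-4-yl)carbonyl)amino gives a 2.0-fold higher number from compound 1 to compound 4 (0.31 log units; beyond the scatter), so both ring-bearing groups stand ahead of methylcarbamoyl at this position. The comparison with the ring-free aminomethyl amide gives a 1.3-fold lower number from compound 3 to compound 4 (0.12 log units; within the scatter), which means that the amine of compound 3 brings no gain that can be told apart from methylcarbamoyl, a group without one. No measurement here explains these shifts.

The compounds shown do not separate the contribution of the ring's carbon atoms from that of its nitrogen, which a cyclohexyl amide could test. A longer chain such as 2-aminoethyl would show whether an amine set further out on an open chain behaves more like the piperidines.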